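Trifluoromethyl in place of isopropyl on a urea series

This account rests on a few compounds, and the source may have more. Where it says the series, first, only, none or still open, it means among the compounds named here.

Of the compounds shown here, three with a shared core have been measured. In an assay on microsomes for inhibition of acyl-CoA:cholesterol acyltransferase (Oryctolagus cuniculus) (on this read-out lower numbers stand for stronger inhibition and higher numbers for weaker inhibition), compound 1 `Cc1cccc(C2(CNC(=O)Nc3c(C(C)C)cccc3C(C)C)CCCC2)c1` gives 15 nM, compound 2 `CC(C)c1ccc(C2(CNC(=O)Nc3c(C(C)C)cccc3C(C)C)CCCC2)cc1` gives 48 nM and compound 3 `CC(C)c1cccc(C(C)C)c1NC(=O)NCC1(c2ccc(OCc3ccccc3)cc2)CCCC1` gives 34 nM. Compound 2 holds the highest of these three numbers: a 3.2-fold higher number from compound 1 to compound 2 (0.51 log units; beyond the scatter), whereas a 1.4-fold lower number from compound 2 to compound 3 (0.15 log units; within the scatter). Compound 4 `CC(C)c1cccc(C(C)C)c1NC(=O)NCC1(c2ccc(C(F)(F)F)cc2)CCCC1` differs from compound 2 in one place: trifluoromethyl in place of isopropyl on an aromatic carbon. Going by the values given here, no measured step involves trifluoromethyl. The nearest guide is the other exchange on an aromatic carbon, a 1.4-fold lower number from compound 2 to compound 3 (0.15 log units; within the scatter), which stayed within the scatter. A step beyond the scatter in this assay is therefore not expected. The expected step is a 1.2-fold lower number from compound 2 to compound 4 (0.08 log units; within the scatter). Compound 4 is estimated at 40 nM, with a range from 15 nM to 110 nM.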

Compound 4, half-maximal inhibitory concentration: 66 nM
Beside the measured number, compound 4's estimate is 1.7-fold (0.22 log units) below it; the range from low to high includes it.
By their numbers in this assay, from the lowest: compound 1; then compounds 3, 2 and 4 (each within the scatter of the next).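

Trifluoromethyl at this aromatic carbon stays within the scatter of both earlier groups in this assay, with a 1.4-fold higher number from compound 2 to compound 4 (0.14 log units; within the scatter) and a 1.9-fold higher number from compound 3 to compound 4 (0.29 log units; within the scatter), so this position has now taken three different groups without a clear change in the number. Going by these compounds alone, the larger gap is the one that also changes the aryl group's substitution, a 4.4-fold higher number from compound 1 to compound 4 (0.64 log units; beyond the scatter), and it lies beyond the scatter. No measurement at hand explains these numbers. On these data alone, whether an amine or a carboxylic acid on this aromatic carbon would also leave the number in this range remains open.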